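The source may hold more compounds than are shown below. What is called first, only, known or untested is meant among the compounds shown, and "the series" means these compounds.

Of the compounds shown here, three of one shared core have been tested in a functional assay on HCC1806 cells (Homo sapiens) for inhibition, read by sulforhodamine B assay, tested at 10 uM; on this read-out higher numbers stand for more inhibition at the one concentration tested (going by the name of the read-out) and lower numbers for less inhibition. Compound 3 `C=C(C)C(=O)N1N=C(c2ccc(-n3ccnc3)cc2)CC1c1ccc(N(C)C)cc1` gives 1.6%. Compound 2 `CN(C)c1ccc(C2CC(c3ccc(-n4ccnc4)cc3)=NN2C(=O)CCCl)cc1` gives -5.2%, and compound 1 `COC(=O)CC(=O)N1N=C(c2ccc(-n3cncn3)cc2)CC1c1ccc(N(C)C)cc1` gives -7.8%. All three numbers lie close to zero on this read-out, and the gaps between them fall within the scatter of the measurement, so the inhibition in this assay is level across the three compounds; the number of compound 3 is merely the one that sits at the top of a tight cluster.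

Compound 4 `COC(=O)CC(=O)N1N=C(c2ccc(-n3ccnc3)cc2)CC1c1ccc(N(C)C)cc1` is not yet measured. It differs from compound 3 at a single place: (methoxycarbonyl)methyl in place of 1-methylethenyl on a carbonyl carbon. For the measured compounds named here, compound 1 carries this same (methoxycarbonyl)methyl group, though it differs from compound 4 elsewhere, so no single step links the two.

Going by the values given here, the only measured step at this carbonyl carbon is a number 6.8 percentage points higher from compound 2 to compound 3 (within the scatter), which is a change within the scatter. Exchanging the acyl group once more is therefore expected to move this assay by nothing beyond the scatter, and the step of a number 4.6 percentage points lower from compound 3 to compound 4 (within the scatter) is the estimate that follows. Compound 4 is expected to give about -3% in this assay, with a likely range from -15% to 10%.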

Compound 4, a percentage reported as inhibition, at one concentration (the size of the read-out at that concentration, not a potency): 2.1%
Beside the measured number, compound 4's estimate is 5.1 percentage points below it; low and high end bracket the measured number.
By their numbers in this assay, from the lowest: compounds 1, 2, 3 and 4 (each within the scatter of the next).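

In this assay, placing (methoxycarbonyl)methyl on the carbonyl carbon where 1-methylethenyl stood gives a number 0.5 percentage points higher from compound 3 to compound 4 (within the scatter), so a group with hydrogen-bond acceptors and a group with none read alike at this position. The change further out on the same acyl chain, methoxycarbonyl in place of chloromethyl on a saturated chain carbon bound to a carbonyl carbon, gives a number 7.3 percentage points higher from compound 2 to compound 4 (within the scatter), which means that the three acyl groups on the imidazole-bearing compounds are not told apart by this measurement. For the compounds shown here, the result also supplies the first step at a second place in the molecule: 1H-imidazol-1-yl in place of 1H-1,2,4-triazol-1-yl on an aromatic carbon gives a number 9.9 percentage points higher from compound 1 to compound 4 (within the scatter), so this exchange of aromatic groups does not separate the compounds either.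

The compounds shown leave open whether any acyl group on this carbonyl carbon, such as one ending in an amine, a carboxylic acid or a longer chain, would lift the read-out clear of the cluster near zero. Nothing measured alongside these numbers accounts for how level they are.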